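This account rests on a few compounds, and the source may have more. Where it says the series, first, only, none or still open, it means among the compounds named here.

Working notes on the series in a functional assay on U-87MG ATCC cells for antiproliferative activity against U-87 MG (Homo sapiens), read by MTT assay, with a stated time of 48 h; a lower number here means a stronger inhibitor, a higher number a weaker inhibitor: compound 1 `COc1ccc(-c2nc(C)c(C(=O)CSc3nc(N)c(C#N)c(-c4ccc(Cl)cc4)n3)s2)cc1` gives 4540 nM, compound 2 `Cc1nc(-c2ccc(Cl)cc2)sc1C(=O)CSc1nc(-c2ccccc2)c(C#N)c(=O)[nH]1` gives 27600 nM and compound 3 `Cc1nc(-c2ccccc2)sc1C(=O)CSc1nc(-c2ccccc2)c(C#N)c(=O)[nH]1` gives 56600 nM. Compound 2 is thus the second highest of the three numbers. Compound 4 `COc1ccc(-c2nc(SCC(=O)c3sc(-c4ccc(Cl)cc4)nc3C)[nH]c(=O)c2C#N)cc1OC` follows from compound 2 by one change, (3,4-dimethoxyphenyl in place of phenyl on an aromatic carbon), with 3,4-dimethoxyphenyl in place of phenyl, ortho to a cyano group. For the measured compounds named here, the only measured step, a 2.1-fold higher number from compound 2 to compound 3 (0.31 log units; beyond the scatter), is modest and does not touch the phenyl replaced here, so it offers only a rough guide to size. Going by the values given here, no measured step covers this place. A small move to a lower number is expected in this assay. The estimated step is a 1.8-fold lower number from compound 2 to compound 4 (0.26 log units; within the scatter). Compound 4 is expected at 15000 nM, within an estimated range of 5000 nM to 45000 nM.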

Compound 4, half-maximal inhibitory concentration: 38600 nM
Estimate against measurement, compound 4: 2.6-fold (0.41 log units) below; the measured number falls inside the stated range.
By their numbers in this assay, from the lowest: compound 1; then compounds 2, 4 and 3 (each within the scatter of the next, the first and the last beyond it).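

In this assay, a 1.4-fold higher number from compound 2 to compound 4 (0.15 log units; within the scatter) stays within the scatter, so compound 4 cannot be told apart from compound 2. For the compounds shown here, this is the first reading at this place, ortho to a cyano group: the larger 3,4-dimethoxyphenyl, with its added oxygen atoms, brings no gain or loss that this assay can resolve.

From the compounds shown here alone, whether a pyridyl ring or a phenyl carrying a carboxylic acid at this place would move the number stays open. No evidence is at hand to explain this flat result.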